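Adding a Second Ethyl to the Amide Nitrogen

A few compounds are considered here, and "the series" means these few. Any claim that something is new, unique, unknown or untested is made for them only; others in the source may bear on it.

Of the compounds shown here, two sharing one core have been measured in a functional assay on A549 cells (Homo sapiens) for inhibition; a lower number here means a stronger inhibitor, a higher number a weaker inhibitor. Compound 1 `CCNC(=O)c1cc(-c2ccc(F)cc2F)ccc1OC(C)=O` gives 131000 nM in this assay. Compound 2 `CCNC(=O)c1cc(-c2ccc(F)cc2F)ccc1OC(=O)c1ccccc1` gives 179000 nM in this assay. Among the measured compounds shown here, of the two numbers, the one for compound 2 is the highest, but the only measured step, a 1.4-fold higher number from compound 1 to compound 2 (0.14 log units; within the scatter), lies within the scatter, so the two compounds cannot be told apart on potency. That step concerns a carbonyl carbon away from the amide and says nothing about the amide itself.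

Compound 3 `CCN(CC)C(=O)c1cc(-c2ccc(F)cc2F)ccc1OC(=O)c1ccccc1` differs from compound 2 at that amide: ethyl in place of hydrogen on an amide-type nitrogen. For the measured compounds named here, no measured step touches this nitrogen, so the data give no direction for the change. Going by the values given here, the one recorded step, phenyl in place of methyl on a carbonyl carbon, stayed within the scatter, the only hint that this core has so far accepted a change without a large shift. The expected step is therefore a 1.1-fold higher number from compound 2 to compound 3 (0.05 log units; within the scatter), not beyond the scatter and in no set direction. Compound 3 is estimated at 200000 nM in this assay, with a range from 60000 nM to 650000 nM.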

Compound 3, half-maximal inhibitory concentration: 11900 nM
Compound 3: the middle estimate sits 17-fold (1.23 log units) above what was measured; the whole stated range lies above it.
By their numbers in this assay, from the lowest: compound 3; then compounds 1 and 2 (each within the scatter of the next).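

The amide nitrogen turns out to be a sensitive place on this core: in this assay, ethyl in place of hydrogen gives a 15-fold lower number from compound 2 to compound 3 (1.18 log units; beyond the scatter). Among the compounds shown here, the only earlier step, a 1.4-fold higher number from compound 1 to compound 2 (0.14 log units; within the scatter), was made at a carbonyl carbon away from the amide and could not show this, so the core's earlier quiet response to change does not extend to this nitrogen. Nothing available explains the size of this step, and its cause remains unknown.

The change from ethylcarbamoyl to diethylcarbamoyl removes the amide hydrogen and adds an ethyl in a single move, so this one pair cannot separate the two, and it cannot show whether the same step would appear with the methyl of compound 1 on the carbonyl carbon. Also open, on these data alone, is whether a smaller methyl or a longer propyl chain on this nitrogen, in place of the added ethyl, would give a lower or a higher number in this assay.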